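Anilide replacement of the benzothiophenylmethyl amide: plasma exposure

The compounds below may be only part of what the source reports. "The series", "measured", "known", "first", "only" and "open" are said of these compounds alone.

These notes cover an aminomethyl-pyridyl ether series with a trifluoromethyl group on the shared core, read out in an ADME assay on the whole organism (plasma, Mus musculus) for pharmacokinetics, read by LC-MS, at a dose of 30 mg/kg by the oral route; a lower number here means less compound in the circulation, a higher number more compound in the circulation at the dose given. Compound 1 `NCc1cc(Oc2cccc(C(=O)NCCS(N)(=O)=O)c2)nc(C(F)(F)F)c1`, carrying a sulfonamide-bearing ethyl amide, gives 1040 nM in this assay. Compound 3 `NCc1cc(O[C@H]2CCCN(C(=O)Nc3ccccc3)C2)nc(C(F)(F)F)c1`, in which the aryl ether is exchanged for a piperidinyl ether with a phenyl urea, gives 1900 nM in this assay. The two numbers sit within the usual scatter of each other, so no order between compound 1 and compound 3 is read from them. Compound 2 `NCc1cc(Oc2cccc(C(=O)NCc3cc4ccccc4s3)c2)nc(C(F)(F)F)c1`, the (1-benzothiophen-2-yl)methyl amide, gives "not determined" (no result reported) in this assay, so it stands without a number and cannot anchor a step.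

Compound 4 `NCc1cc(Oc2cccc(C(=O)Nc3ccccc3)c2)nc(C(F)(F)F)c1` is the next member. It differs from compound 2 by phenyl in place of (1-benzothiophen-2-yl)methyl on an amide-type nitrogen. Among the measured compounds shown here, with no measured pair sharing this change, and with the two measured members lying close together, no step beyond the scatter is expected in either direction for this assay; the anilide is expected to land in the same band as compound 1 and compound 3. Compound 4 is therefore estimated at 1400 nM in this assay, with a range from 400 nM to 5000 nM.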

Compound 4, maximal plasma concentration: 860 nM
Compound 4: middle estimate off by 1.6-fold (0.21 log units), on the high side; the measured number falls inside the stated range.
By their numbers in this assay, from the lowest: compounds 4, 1 and 3 (each within the scatter of the next, the first and the last beyond it).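

Among the compounds shown here, on the amide-type nitrogen, phenyl in place of 2-sulfamoylethyl gives a 1.2-fold lower number from compound 1 to compound 4 (0.08 log units; within the scatter) in this assay, and this is the first pair that differs in one place and has a number at both ends. At this position, then, a phenyl group placed directly on the nitrogen and a 2-sulfamoylethyl chain are not separated by this read-out, although the two groups share little beyond their attachment; the step from compound 2 to compound 4 cannot be read, as compound 2 has no number. Nothing available accounts for this lack of separation, and no measured property of either group bears on it.

From the compounds shown here alone, whether the (1-benzothiophen-2-yl)methyl group departs from either of these two groups therefore remains unknown, and one pair cannot define the range of this position. Also open, going by these compounds, is how this read-out responds at the same nitrogen to a carboxylic acid or a tertiary amine at the end of a longer chain, or to a fluorine on the phenyl ring.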